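The source may report more compounds than this note shows. Statements on the series, on what has been measured and on what is new or still open speak of the compounds shown alone.

Compound 1 `CCCCCCCCCCCCCCOC(=O)CCC(=O)N1CCN(CCCOc2cc3c(Nc4ccc(F)c(Cl)c4)ncnc3cc2OC)CC1` is the shorter-chain ester of this pair and in a functional assay on A549 cells (Homo sapiens) for cytotoxicity, read by MTT assay, with a stated time of 24 h, tested at 60 uM (on this read-out higher numbers stand for a weaker effect at the one concentration tested and lower numbers for a stronger effect), compound 1 gives 84.9%. Compound 2 `CCCCCCCCCCCCCCCCCOC(=O)CCC(=O)N1CCN(CCCOc2cc3c(Nc4ccc(F)c(Cl)c4)ncnc3cc2OC)CC1` carries the same core with a longer ester chain, and in this assay compound 2 gives 84.1%. Within the data shown here, the one step between them, a number 0.8 percentage points lower from compound 1 to compound 2 (within the scatter), lies within the scatter, so compound 2 stands alongside compound 1 without a difference that the read-out can separate. Compound 3 `CCCCCCCCCCCCCCCCCCCCOC(=O)CCC(=O)N1CCN(CCCOc2cc3c(Nc4ccc(F)c(Cl)c4)ncnc3cc2OC)CC1` extends the same ester chain once more; the change from compound 2 is propyl in place of hydrogen on a saturated chain carbon, ten or more bonds along the chain from an oxygen next to a carbonyl group. Among the measured compounds shown here, the only measured step that bears on this change is the one from compound 1 to compound 2, which is the same kind of chain lengthening, and it was a number 0.8 percentage points lower from compound 1 to compound 2 (within the scatter). On that basis the expected step is a number 0.1 percentage points lower from compound 2 to compound 3 (within the scatter), that is, no change beyond the scatter in either direction, because the earlier step of a number 0.8 percentage points lower from compound 1 to compound 2 (within the scatter) showed none. The estimate for compound 3 in this assay is therefore 84%, with a range from 74% to 94%.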

Compound 3, a percentage reported as activity, at one concentration (the size of the read-out at that concentration, not a potency): 86.9%
For compound 3 the middle estimate is 2.9 percentage points below the measured one, within the range that was stated.
By their numbers in this assay, from the lowest: compounds 2, 1 and 3 (each within the scatter of the next).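

In this assay, a second addition of propyl in place of hydrogen on a saturated chain carbon, ten or more bonds along the chain from an oxygen next to a carbonyl group, comes to a number 2.8 percentage points higher from compound 2 to compound 3 (within the scatter), so this change has now been read twice on the ester chain and neither reading leaves the scatter. Taken as a whole, hexyl in place of hydrogen at that same place comes to a number 2 percentage points higher from compound 1 to compound 3 (within the scatter), which means that even the widest span of chain length in this series does not separate the three esters on this read-out. Nothing available bears on why the numbers for these three chains cannot be told apart.

The compounds shown leave open whether a much shorter chain, such as a methyl ester, or a carboxylic acid in place of the ester, would give a number that stands apart from these three beyond the scatter. They also leave open whether an amine at the far end of the chain would move the read-out at this position.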